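This account rests on a few compounds, and the source may have more. Where it says the series, first, only, none or still open, it means among the compounds named here.

Measured compounds in this series:

compound 1, `Cn1c(/C=C/C(=O)c2ccccc2O)cc(Br)c1Br`, 3160 nM
compound 2, `Cn1c(/C=C/C(=O)c2ccc[nH]2)cc(Br)c1Br`, >= 100000 nM
compound 3, `O=C(/C=C/c1cc(Br)c(Br)[nH]1)c1ccccc1O`, >= 100000 nM

The read-out throughout is a functional assay on Caco-2 cells (Homo sapiens) for cytotoxicity, read by MTT assay, with stated times of 6 h and 48 h; on this read-out lower numbers stand for stronger inhibition and higher numbers for weaker inhibition. Compound 1 gives 3160 nM in this assay. For compound 3 the result in this assay is a limit of the assay, >= 100000 nM, and not a number. For compound 2 the result in this assay is likewise a limit, >= 100000 nM. Two of the three values sit at that limit: the limit of >= 100000 nM in this assay, at which 2 of the 3 values shown sit.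

Compound 1 and compound 3 differ in one place, (hydrogen in place of methyl on an aromatic nitrogen). The step is an at least 31-fold higher number from compound 1 to compound 3 (1.50 log units; beyond the scatter).

Compound 4, `O=C(/C=C/c1cc(Br)c(Br)[nH]1)c1ccc[nH]1`, is not yet measured in this assay. It stands to compound 2 as compound 3 stands to compound 1: hydrogen in place of methyl on an aromatic nitrogen. The surroundings are not word for word the same: in compound 1 the changed nitrogen is next to the ring atom that bears a large group, in compound 2 next to the ring atom that bears a group of 9 heavy atoms, so the change is of the same kind rather than the same. How the core of compound 1 and the core of compound 2 differ is not broken down here.

Compound 2 already sits at a limit, and the same kind of change moved compound 1 to a limit. Compound 4 is therefore expected to report a limit as well, a step of a number no higher from compound 2 to compound 4 (the limit leaves the size open), because the earlier step was an at least 31-fold higher number from compound 1 to compound 3 (1.50 log units; beyond the scatter) in the weakening direction. The estimate for compound 4 in this assay is 100000 nM, with 50000 nM to 300000 nM as the expected span.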

Compound 4, half-maximal inhibitory concentration: >= 100000 nM
Compound 4: a limit, no number (the forecaster's own chance of this, stated with the estimate: 85%); the middle value lies on the limit itself.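

In this assay compound 4 gives >= 100000 nM, a limit of the assay and not a number. Compound 2 also sits at a limit, so no new step can be read between compound 2 and compound 4. The compounds shown leave open whether hydrogen in place of methyl on an aromatic nitrogen changes the read-out at all on the core of compound 2: the limit of >= 100000 nM in this assay, at which 3 of the 4 values shown sit.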